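Swapping methoxy for hydrogen on compound 2

A few compounds are considered here, and "the series" means these few. Any claim that something is new, unique, unknown or untested is made for them only; others in the source may bear on it.

In a physicochemical assay for acid dissociation, compound 1 (`COc1cccc(CNCCCNc2ccnc3cc(Oc4ccccc4)ccc23)c1O`) reads 9.28 and compound 2 (`COc1cccc(Oc2ccc3c(NCCCNCc4ccco4)ccnc3c2)c1`) reads 9.28 as well, so compound 2 stands level with compound 1 and no gap separates them at the digits shown.

Compound 3 (`c1ccc(Oc2ccc3c(NCCCNCc4ccco4)ccnc3c2)cc1`) is compound 2 with hydrogen in place of methoxy on an aromatic carbon, which turns 3-methoxyphenoxy into phenoxy (hydrogen in place of methoxy on an aromatic carbon). Within the data shown here, no two measured compounds show this change on its own, so the data give no direct size for it. The expected step in this assay is none beyond the scatter. Compound 1 already carries phenoxy where compound 2 carries 3-methoxyphenoxy, and compound 1 at 9.28 and compound 2 at 9.28 read alike, although the two also differ elsewhere. The estimated step is therefore close to nothing (no change at the digits printed from compound 2 to compound 3 (within the scatter)). The estimate for compound 3 is an expected 9.28 (range 9 to 9.55).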

Compound 3, acid dissociation constant: 9.28
The estimate for compound 3 equals the measured number at the digits printed, within the range that was stated.
By their numbers in this assay, from the lowest: compounds 1, 2 and 3 (each within the scatter of the next).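

In this assay, among these compounds, the step that swaps methoxy for hydrogen on the aromatic carbon gives no change at the digits printed from compound 2 to compound 3 (within the scatter), which is the first direct reading of this change on its own, free of differences elsewhere in the molecule. Furan-2-yl in place of 2-hydroxy-3-methoxyphenyl on the saturated chain carbon bound to an amine nitrogen gives no change at the digits printed from compound 1 to compound 3 (within the scatter), so neither single-place change separates these compounds in this assay. Nothing available explains either result.

From the compounds shown here alone, whether an amine or a carboxylic acid in place of methoxy on that aromatic carbon, or a longer chain carrying the amine nitrogen, would shift the reading remains open. The compounds shown also leave open which proton in these molecules the reading belongs to.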